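The source may hold more compounds than are shown below. What is called first, only, known or untested is meant among the compounds shown, and "the series" means these compounds.

Measured so far:
- Compound 1 `CC(=O)Nc1ccc2oc(-c3ccccc3F)cc(=O)c2c1`: 205000 nM
- Compound 2 `CC(=O)Nc1ccc2oc(-c3cccc(F)c3)cc(=O)c2c1`: 240000 nM

Both numbers come from an ADME assay on MT4 cells (Homo sapiens) for cytotoxicity, read by MTT assay, with a stated time of 4 days; on this read-out lower numbers stand for higher toxicity in this test and higher numbers for lower toxicity in this test. Among the measured compounds shown here, only two compounds have been measured, so compound 2 has just one neighbour, and a 1.2-fold higher number from compound 1 to compound 2 (0.07 log units; within the scatter). Compound 2 therefore cannot be set apart from compound 1 on these data.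

The next compound, compound 3 `CC(=O)Nc1ccc2oc(-c3ccc(F)cc3)cc(=O)c2c1`, keeps the shared core and has 4-fluorophenyl in place of 3-fluorophenyl on an aromatic carbon. For the measured compounds named here, only one measured step bears on this swap: a 1.2-fold higher number from compound 1 to compound 2 (0.07 log units; within the scatter). It also exchanges one fluorophenyl group for another, and it stays within the scatter. Going by the values given here, a single step is thin evidence, and no measured compound yet carries 4-fluorophenyl. Even so, no step beyond the scatter is expected in this assay, in either direction. The estimated step is a 1.1-fold lower number from compound 2 to compound 3 (0.04 log units; within the scatter), which would be too small to separate the two compounds. The expected value for compound 3 is 220000 nM, with an estimated range from 130000 nM to 370000 nM.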

Compound 3, half-maximal cytotoxic concentration: 203000 nM
Compound 3: the middle estimate sits 1.1-fold (0.03 log units) above what was measured; the range from low to high includes it.
By their numbers in this assay, from the lowest: compounds 3, 1 and 2 (each within the scatter of the next).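

With compound 3, the shared core has now been tested with 2-fluorophenyl, 3-fluorophenyl and 4-fluorophenyl on the same aromatic carbon, next to the ring oxygen. In this assay, the change to 4-fluorophenyl gives a 1.2-fold lower number from compound 2 to compound 3 (0.07 log units; within the scatter), and the comparison with the 2-fluorophenyl compound gives a 1.0-fold lower number from compound 1 to compound 3 (0.00 log units; within the scatter), so both steps lie within the scatter and the three compounds cannot be told apart in this test. Moving the fluorine around this phenyl ring therefore leaves the read-out unresolved for all three compounds, and no supporting measurement is available that could explain this result.

All three compounds carry a single fluorine on a phenyl ring at this carbon, so they do not show whether the fluorine itself matters, or whether a plain phenyl, a methoxyphenyl or an aminophenyl group here would give a step beyond the scatter. They also leave open what would happen if the rest of the shared core changed, for example with a carboxylic acid or a longer chain in place of the group that all three compounds share.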